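The source may report more compounds than this note shows. Statements on the series, on what has been measured and on what is new or still open speak of the compounds shown alone.

Measured so far in an assay on CHO-K1 cells for displacement of a labelled ligand from adenosine receptor A1 (Homo sapiens), read by scintillation counting, with a stated time of 60 min; a higher number here means a weaker inhibitor, a lower number a stronger inhibitor:

Compound 1, `Nc1nc(N/N=C/c2cccc(OCc3ccccc3)c2)nc2c1ncn2[C@@H]1O[C@H](CO)[C@@H](O)[C@H]1O`, gives 13 nM.
Compound 2, `CCOc1cc(/C=N/Nc2nc(N)c3ncn([C@@H]4O[C@H](CO)[C@@H](O)[C@H]4O)c3n2)ccc1O`, gives 6940 nM.
Compound 3, `Nc1nc(N/N=C/c2ccc(OCc3ccccc3)c(OCc3ccccc3)c2)nc2c1ncn2[C@@H]1O[C@H](CO)[C@@H](O)[C@H]1O`, gives only a limit of the assay, > 10000 nM.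

Among the two numbers that are not limits, compound 2 stands highest, and compound 1 stands lowest; the gap between them is beyond the scatter. Among the measured compounds shown here, the one step measured between single-point neighbours is an at least 760-fold higher number from compound 1 to compound 3 (2.88 log units; beyond the scatter), a large loss, and the limit of > 10000 nM in this assay, at which 1 of the 3 values shown sits, marks where compound 3 sits.

Compound 4, `Nc1nc(N/N=C/c2ccc(-n3ccnc3)cc2)nc2c1ncn2[C@@H]1O[C@H](CO)[C@@H](O)[C@H]1O`, is the next compound to be measured in this assay. It differs from compound 2 by 4-(1H-imidazol-1-yl)phenyl in place of 3-ethoxy-4-hydroxyphenyl on a carbon with a double bond to nitrogen. For the measured compounds named here, no measured step covers this exchange: the only measured step concerns a benzyloxy group, and neither an imidazolyl nor the removal of a hydroxy group has been tested. The values of compound 1 and compound 2 show that the aryl substituent can move the number over a wide span in either direction. Going by the values given here, with no direct precedent, compound 4 is expected to come out somewhat stronger than compound 2, by about a 4.6-fold lower number from compound 2 to compound 4 (0.67 log units; beyond the scatter), though the uncertainty is wide. Compound 4 is therefore estimated at 1500 nM, within a range from 150 nM to 10000 nM.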

Compound 4, inhibition constant: > 10000 nM
Compound 4 was reported as a limit (the forecaster's own chance of this, stated with the estimate: 15%); middle value at least 6.6-fold (0.82 log units) from the limit.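

In this assay, the exchange on this carbon brings an at least 1.4-fold higher number from compound 2 to compound 4 (0.15 log units; that floor lies within the scatter), so it yields no gain in strength, while the size of any loss remains unsettled. Compound 4 is recorded only as a limit of the assay, not as a number, making it the second compound at that limit: the limit of > 10000 nM in this assay, at which 2 of the 4 values shown sit. This is the first exchange shown at this place that removes the hydroxy and ethoxy groups and introduces an imidazolyl ring, and it does not bring the number below that of compound 2, which gives 6940 nM.

The compounds shown leave open how far compound 4 actually lies from compound 2. They also leave open whether a dimethylamino group or a carboxylic acid in place of the imidazolyl ring would give a stronger inhibitor.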